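The source may hold more compounds than are shown below. What is called first, only, known or untested is meant among the compounds shown, and "the series" means these compounds.

In an ADME assay on BHK15 cells (Mesocricetus auratus) for inhibition, read by XTT assay, with a stated time of 36 h (on this read-out lower numbers stand for stronger inhibition of growth and higher numbers for weaker inhibition of growth), compound 1, `CNC(=O)c1sc(-c2ccc(Cl)cc2)nc1C(Br)Br`, gives 74600 nM, while compound 2, `CCNC(=O)c1sc(-c2ccc(Cl)cc2)nc1C(Br)Br`, gives 33300 nM. The change between them, (methyl in place of hydrogen on a saturated chain carbon bound to an amide-type nitrogen), produced a 2.2-fold lower number from compound 1 to compound 2 (0.35 log units; beyond the scatter). Compound 3, `CCOC(=O)c1sc(-c2ccc(Cl)cc2)nc1C(Br)Br`, gives 94600 nM in this assay; it differs from compound 1 by ethoxy in place of methylamino on a carbonyl carbon, and the step between them was a 1.3-fold higher number from compound 1 to compound 3 (0.10 log units; within the scatter). From compound 2 to compound 3 the step was a 2.8-fold higher number from compound 2 to compound 3 (0.45 log units; beyond the scatter).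

Compound 4, `CC(C)OC(=O)c1sc(-c2ccc(Cl)cc2)nc1C(Br)Br`, has not yet been measured. Going by the values given here, it differs from compound 3 by methyl in place of hydrogen on a saturated chain carbon bound to an oxygen next to a carbonyl group and a saturated chain carbon, which is the same kind of change as the one from compound 1 to compound 2, though not the same: there the methyl entered on a saturated chain carbon bound to an amide-type nitrogen, here it enters on a saturated chain carbon bound to an oxygen next to a carbonyl group and a saturated chain carbon. Because the analogous change gave a 2.2-fold lower number from compound 1 to compound 2 (0.35 log units; beyond the scatter), the step from compound 3 to compound 4 is expected to be a 1.6-fold lower number from compound 3 to compound 4 (0.20 log units; within the scatter), resting on a single pair and on a different surrounding. Compound 4 is therefore estimated at 60000 nM in this assay, with a range of 25000 nM to 150000 nM.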

Compound 4, concentration for 50% growth inhibition: 372000 nM
Compound 4: the middle estimate sits 6.2-fold (0.79 log units) below what was measured, outside the stated range (above it).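

In this assay, the added methyl did not carry over from the pair with an amide-type nitrogen to the pair with an oxygen on the carbonyl carbon: the same change on two cores in this assay, a 2.2-fold lower number (0.35 log units; beyond the scatter) from compound 1 to compound 2 and a 3.9-fold higher number (0.59 log units; beyond the scatter) from compound 3 to compound 4, 8.8-fold (0.94 log units) apart, beyond the scatter of two such steps The new step, a 3.9-fold higher number from compound 3 to compound 4 (0.59 log units; beyond the scatter), therefore runs against the earlier one, and isopropoxy also stands well apart from both amino groups, with an 11-fold higher number from compound 2 to compound 4 (1.05 log units; beyond the scatter) and a 5.0-fold higher number from compound 1 to compound 4 (0.70 log units; beyond the scatter). This shows that the step cannot be transferred between these two surroundings in this series, but with a single pair on each side it does not show why they differ, nor whether the same split would hold for other pairs.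

As far as these compounds go, it remains open whether isopropylamino on the carbonyl carbon would follow the step from methylamino to ethylamino or the step from ethoxy to isopropoxy. Also open, from the compounds shown here alone, is how a carboxylic acid or a longer chain such as butoxy in that place would read.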